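The source may report more compounds than this note shows. Statements on the series, on what has been measured and on what is new or still open speak of the compounds shown alone.

compound 1 `Cc1ccccc1C1CC(c2ccc(OCc3ccccc3)cc2)=NN1c1ccc(S(N)(=O)=O)cc1`: 20000 nM
compound 2 `NS(=O)(=O)c1ccc(N2N=C(c3ccc(OCc4ccccc4)cc3)CC2c2ccc(F)cc2)cc1`: 60000 nM

Within the data shown here, in an ADME assay on BHK-21 cells (Mesocricetus auratus) for cytotoxicity, read by MTT assay, with a stated time of 72 h (a higher number here means that more compound is tolerated, a lower number that less compound is tolerated), compound 2 gives 60000 nM, the higher of the two numbers measured so far, so cells tolerate more of it than of compound 1. The next compound is compound 3 `Cc1ccc(C2CC(c3ccc(OCc4ccccc4)cc3)=NN2c2ccc(S(N)(=O)=O)cc2)cc1`, which keeps the shared core and alters one group: methyl in place of fluoro on an aromatic carbon. In words, this is methyl in place of fluoro on an aromatic carbon, para to a large group, or 4-fluorophenyl to 4-methylphenyl.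

Among the measured compounds shown here, only one measured step bears on this, and only indirectly: a 3.0-fold higher number from compound 1 to compound 2 (0.48 log units; beyond the scatter), with 4-fluorophenyl in place of 2-methylphenyl on a saturated ring carbon. For the measured compounds named here, compound 3 also carries a methylphenyl group, but as 4-methylphenyl, and no measured compound shows that group. A small move back down in this assay is therefore expected, smaller than that modest step and probably within the scatter. The estimated change is a 1.7-fold lower number from compound 2 to compound 3 (0.23 log units; within the scatter), and it rests on very little evidence. For compound 3 the expected value is 35000 nM, with an estimated range from 15000 nM to 80000 nM, still to be tested by measurement.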

Compound 3, half-maximal cytotoxic concentration: 32000 nM
Beside the measured number, compound 3's estimate is 1.1-fold (0.04 log units) above it, within the range that was stated.
By their numbers in this assay, from the lowest: compounds 1, 3 and 2 (each within the scatter of the next, the first and the last beyond it).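

In this assay, putting methyl in place of fluoro on this aromatic carbon, para to a large group, gives a 1.9-fold lower number from compound 2 to compound 3 (0.27 log units; within the scatter) and so does not separate compound 3 from compound 2. Moving the methyl, with 4-methylphenyl in place of 2-methylphenyl, gives a 1.6-fold higher number from compound 1 to compound 3 (0.20 log units; within the scatter) and so does not separate compound 3 from compound 1 either, even though compound 1 and compound 2 lie beyond the scatter of each other; neither single change can therefore be read as a real effect on how much compound the cells tolerate. Nothing measured here offers an explanation for these numbers.

Going by these compounds, it remains open whether a clearly different group on the same aromatic carbon, such as a hydroxyl, an amine or a carboxylic acid, would shift the number beyond the scatter in either direction. Also open, on these data alone, is how fluoro would behave in the position of the methyl in compound 1, as a 2-fluorophenyl group, which would show whether the position or the group matters more.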